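The source may report more compounds than this note shows. Statements on the series, on what has been measured and on what is new or still open speak of the compounds shown alone.

Measured so far in a functional assay on CWR22R cells (Homo sapiens) for antiproliferative activity, read by CCK-8 assay, with a stated time of 6 days; a lower number here means a stronger inhibitor, a higher number a weaker inhibitor:
- compound 1 `CCN(c1ccc(C#N)c(Cl)c1)c1cc(-c2ccncc2)ccc1C`: 1030 nM
- compound 2 `CCN(c1ccc(C#N)c(Cl)c1)c1cc(-c2ccco2)ccc1C`: > 30000 nM, a limit
- compound 3 `CCN(c1ccc(C#N)c(Cl)c1)c1cc(-c2cncnc2)ccc1C`: > 30000 nM, a limit

Compound 3 has no number in this assay, only (the limit of > 30000 nM in this assay, at which 2 of the 3 values shown sit). Compound 4 `CCN(c1ccc(C#N)c(Cl)c1)c1cc(-c2ccc(F)nc2)ccc1C` carries 6-fluoropyridin-3-yl in place of pyrimidin-5-yl on an aromatic carbon. Among the measured compounds shown here, two measured steps bear on this change, both large: an at least 29-fold higher number from compound 1 to compound 2 (1.46 log units; beyond the scatter), and an at least 29-fold higher number from compound 1 to compound 3 (1.46 log units; beyond the scatter). Only the pyridine compound 1 gives a number, 1030 nM, and compound 4 is also a pyridine, so a large move to a lower number is expected, though with little certainty. The expected step is an at least 7.5-fold lower number from compound 3 to compound 4 (0.87 log units; beyond the scatter). For compound 4 the estimated value is 4000 nM, with an expected range of 800 nM to 20000 nM.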

Compound 4, half-maximal inhibitory concentration: 16500 nM
Compound 4: middle estimate off by 4.1-fold (0.62 log units), on the low side; measured number inside the range.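

In this assay, among the compounds shown here, compound 4 joins compound 1 as the only compounds here with a number rather than a limit, so a pyridine ring at this position can give a measurable value. That value does not match the pyridin-4-yl result, with a 16-fold higher number from compound 1 to compound 4 (1.20 log units; beyond the scatter). Against the limits, an at least 1.8-fold lower number from compound 3 to compound 4 (0.25 log units; that floor lies within the scatter) and an at least 1.8-fold lower number from compound 2 to compound 4 (0.25 log units; that floor lies within the scatter), and both floors lie within the scatter, so neither gain is established.

Going by these compounds, whether the ring attachment or the fluorine separates compound 4 from compound 1 remains open. An unsubstituted pyridin-3-yl, or a fluorinated pyridin-4-yl, would separate the two in this assay.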